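Chloro for Fluoro on the Methylsulfonyl Core

The compounds below may be only part of what the source reports. "The series", "measured", "known", "first", "only" and "open" are said of these compounds alone.

Going by the values given here, compound 1 `CS(=O)(=O)c1ccc(F)cc1NCC1=NCCN1` stands at the high end of the three numbers measured so far: in an assay for binding affinity to Alpha-1D adrenergic receptor (Homo sapiens), read by radioligand binding (a higher number here means a weaker inhibitor, a lower number a stronger inhibitor), compound 1 gives 2630 nM, whereas compound 2 `CSc1ccc(F)cc1NCC1=NCCN1` gives 6.17 nM and compound 3 `CSc1cc(F)ccc1NCC1=NCCN1` gives 5.01 nM. Among the compounds with values here, the only single-point step among the measured compounds is a 430-fold lower number from compound 1 to compound 2 (2.63 log units; beyond the scatter), which puts methylsulfanyl in place of methylsulfonyl; the values of compound 2 and compound 3, which differ in where the fluoro sits, lie within the usual scatter of each other.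

Compound 4 `CS(=O)(=O)c1ccc(Cl)cc1NCC1=NCCN1` departs from compound 1 by chloro in place of fluoro on an aromatic carbon, on an aromatic carbon of a six-membered aromatic ring of carbon only, para to a methylsulfonyl group. Within the data shown here, no measured step swaps one halogen for another, so the large step from compound 1 to compound 2 does not bear on this change, and nothing else measured does either. The expectation in this assay is therefore a step of modest size at most, a 1.3-fold lower number from compound 1 to compound 4 (0.12 log units; within the scatter), quite possibly none beyond the scatter. Compound 4 is estimated at 2000 nM, within a range from 700 nM to 6000 nM.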

Compound 4, inhibition constant: 2400 nM
Compound 4: middle estimate off by 1.2-fold (0.08 log units), on the low side; the range from low to high includes it.
By their numbers in this assay, from the lowest: compounds 3 and 2 (each within the scatter of the next); then compounds 4 and 1 (each within the scatter of the next).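

In this assay, going by these compounds alone, the result gives the first reading of a halogen swap: on the methylsulfonyl core, chloro in place of fluoro para to a methylsulfonyl group gives a 1.1-fold lower number from compound 1 to compound 4 (0.04 log units; within the scatter). At this aromatic carbon, therefore, the two halogens cannot be told apart in this assay, and the step that puts methylsulfanyl in place of methylsulfonyl, a 430-fold lower number from compound 1 to compound 2 (2.63 log units; beyond the scatter), remains the only one shown that lies beyond the scatter. No supporting measurement is available to explain why these two halogens read alike here.

The compounds shown leave open whether chloro and fluoro would also read alike on the methylsulfanyl core of compound 2, where the number is far lower and a small step might show differently. Within the data shown here, they also leave open whether the insensitivity seen here extends beyond the halogens, for instance to a methoxy, a trifluoromethyl or an amine on the same aromatic carbon, since fluoro and chloro are the only groups compared at this place.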